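The source may report more compounds than this note shows. Statements on the series, on what has been measured and on what is new or still open speak of the compounds shown alone.

Compound 1 `O=C(Nc1ccc(C(F)(F)F)cc1)C1CCc2ccccc2N1` is the smaller of the two measured cores, and in a functional assay on HCT-15 cells (Homo sapiens) for cytotoxicity, read by sulforhodamine B assay, with a stated time of 72 h (on this read-out lower numbers stand for stronger inhibition of growth and higher numbers for weaker inhibition of growth), compound 1 gives 17600 nM. Compound 3 `O=C(Nc1ccc(O)cc1)C1CCc2ccccc2N1` differs from compound 1 by hydroxy in place of trifluoromethyl on an aromatic carbon. In this assay compound 3 reaches only a limit, > 100000 nM, because of the limit of > 100000 nM in this assay, at which 1 of the 3 values shown sits. This change gives an at least 5.6-fold higher number from compound 1 to compound 3 (0.75 log units; beyond the scatter). Compound 2 `CCCCCCCCC(=O)N1c2ccccc2CCC1C(=O)Nc1ccccc1C(F)(F)F` carries a further nonanoyl group and a differently placed trifluoromethyl; the difference between the two cores is not broken down here. In this assay compound 2 gives 7700 nM. Compound 4 `CCCCCCCCC(=O)N1c2ccccc2CCC1C(=O)Nc1ccccc1O` differs from compound 2 by hydroxy in place of trifluoromethyl on an aromatic carbon. The place differs in its surroundings, para to a large group in the first pair and ortho to a large group in the second, so this is the same kind of change rather than the same change. An expected step of a 7.8-fold higher number from compound 2 to compound 4 (0.89 log units; beyond the scatter) rests on the earlier step of an at least 5.6-fold higher number from compound 1 to compound 3 (0.75 log units; beyond the scatter) and on the value of compound 2, 7700 nM. Compound 4 is therefore estimated to give 60000 nM in this assay, between 20000 nM and 150000 nM.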

Compound 4, concentration for 50% growth inhibition: 38400 nM
Compound 4: the middle estimate sits 1.6-fold (0.19 log units) above what was measured, within the range that was stated.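

Hydroxy in place of trifluoromethyl on an aromatic carbon again gives a higher number in this assay, with a 5.0-fold higher number from compound 2 to compound 4 (0.70 log units; beyond the scatter), so the change runs the same way on both cores: the same change on two cores in this assay, an at least 5.6-fold higher number (0.75 log units; beyond the scatter) from compound 1 to compound 3 and a 5.0-fold higher number (0.70 log units; beyond the scatter) from compound 2 to compound 4; the limit leaves it open whether they differ Whether the step has the same size on both cores cannot be read, since one end of the earlier step is not a number: the limit of > 100000 nM in this assay, at which 1 of the 4 values shown sits. These are only two pairs, and the changed carbon sits in different surroundings in each, so they show the same kind of change carrying over between these two cores and give no rule for the whole series.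

The compounds shown leave open how an amine, a carboxylic acid or a methoxy group in the same place would compare with trifluoromethyl and hydroxy. They also leave open how a shorter or longer acyl chain would bear on this step, and what the nonanoyl group does on its own, as compound 1 and compound 2 differ in more than one place.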